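Swapping an Ester for a Methoxy Group on an Anilide

The source may hold more compounds than are shown below. What is called first, only, known or untested is meant among the compounds shown, and "the series" means these compounds.

Three compounds share one core, a piperidine carrying an amide on one side and an aryl carbonyl on the other. Compound 1 `O=C(Nc1cccc([N+](=O)[O-])c1)C1CCCN(C(=O)c2cc(C(F)(F)F)cc(C(F)(F)F)c2)C1` gives 9% in an ADME assay on PC-3 cells (Homo sapiens) for cytotoxicity, read by WST assay, tested at 100 uM; a higher number here means more inhibition at the concentration tested (going by the name of the read-out), a lower number less inhibition. Compound 3 `COC(=O)c1cccc(NC(=O)C2CCCN(C(=O)c3cc(C(F)(F)F)cc(C(F)(F)F)c3)C2)c1` gives 0% in this assay, and the step of a number 9 percentage points lower from compound 1 to compound 3 (within the scatter) shows that exchanging these groups left the read-out essentially where it was. Compound 2 `COC(=O)c1cccc(C(=O)N2CCCC(C(=O)Nc3ccc(Cl)cc3)C2)c1` gives 0% in this assay, level with compound 3 at the digits shown, and all three numbers fall within the usual scatter of one another.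

Compound 4 `COc1cccc(C(=O)N2CCCC(C(=O)Nc3ccc(Cl)cc3)C2)c1` differs from compound 2 in one place: methoxy in place of methoxycarbonyl on an aromatic carbon. Within the data shown here, no measured pair changes exactly this group, but the one step available, from compound 1 to compound 3, replaced a group on an aromatic carbon and stayed within the scatter. For compound 4 the expectation is therefore a step of a number 3 percentage points higher from compound 2 to compound 4 (within the scatter), that is, no change beyond the scatter. Compound 4 is expected to give 3% in this assay, within a range of 0% to 14%.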

Compound 4, a percentage reported as inhibition, at one concentration (the size of the read-out at that concentration, not a potency): 0%
Estimate against measurement, compound 4: 3 percentage points above; low and high end bracket the measured number.
By their numbers in this assay, from the lowest: compounds 2, 3, 4 and 1 (each within the scatter of the next).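

Putting methoxy in place of methoxycarbonyl on this aromatic carbon gives no change at the digits printed from compound 2 to compound 4 (within the scatter) in this assay. Among these compounds, the one earlier step changed a group on the anilide, so this is the first measured change on the aryl carbonyl, and there the ester can give way to the smaller methoxy without moving the read-out beyond the scatter. Nothing measured here offers an explanation for this flat result.

Compound 2 already sits at 0%, so this pair could show a rise in the read-out but no fall. Going by these compounds, whether an amine or a carboxylic acid on this aromatic carbon would lift the number in this assay remains open, as does the effect of a longer chain such as ethoxy.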